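The source may hold more compounds than are shown below. What is called first, only, known or untested is meant among the compounds shown, and "the series" means these compounds.

Measured so far:
compound 1 `CC(=O)N[C@@H]1CSSC(C)(C)[C@H](C(N)=O)NC(=O)[C@@H](CC(=O)O)NC(=O)CN(C)C(=O)[C@@H](CCCN=C(N)N)NC1=O` — 73400 nM
compound 2 `CC(=O)N[C@@H]1CSSC(C)(C)[C@H](C(N)=O)NC(=O)[C@@H](CC(=O)O)NC(=O)CN(C)C(=O)[C@@H](CCCN=C(N)N)N(C)C1=O` — 39500 nM
compound 3 `CC(=O)N[C@@H]1CSSC(C)(C)[C@H](C(N)=O)NC(=O)[C@@H](CC(=O)O)NC(=O)CNC(=O)[C@H](CCCN=C(N)N)NC1=O` — 4120 nM

All three were tested in a functional assay (plasma) for inhibition, with Canis familiaris (Canis lupus familiaris) as the target; on this read-out lower numbers stand for stronger inhibition and higher numbers for weaker inhibition. Compound 1 gives 73400 nM, and compound 2, which differs from it by methyl in place of hydrogen on an amide-type nitrogen in a ring, gives 39500 nM; the step is a 1.9-fold lower number from compound 1 to compound 2 (0.27 log units; within the scatter). Compound 3 has another core; how its core differs from that of compound 1 is not broken down here. In this assay compound 3 gives 4120 nM, the lowest of the three numbers, with its steps to the other two beyond the scatter. The unmeasured compound 4 `CC(=O)N[C@@H]1CSSC(C)(C)[C@H](C(N)=O)NC(=O)[C@@H](CC(=O)O)NC(=O)CNC(=O)[C@H](CCCN=C(N)N)N(C)C1=O` arises from compound 3 by methyl in place of hydrogen on an amide-type nitrogen in a ring. This is the same kind of change as that from compound 1 to compound 2, though not the same: the place in compound 1 is also three ring bonds from the ring atom that bears a methyl group, which is not so in compound 3. Because the earlier step was a 1.9-fold lower number from compound 1 to compound 2 (0.27 log units; within the scatter), the step from compound 3 to compound 4 is expected to be small as well, about a 1.4-fold lower number from compound 3 to compound 4 (0.14 log units; within the scatter). Compound 4 is therefore estimated at around 3000 nM, likely between 1000 nM and 10000 nM.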

Compound 4, half-maximal inhibitory concentration: 1790 nM
Compound 4: the middle estimate sits 1.7-fold (0.22 log units) above what was measured, within the range that was stated.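

In this assay, methyl in place of the amide hydrogen on this ring nitrogen gives a 2.3-fold lower number from compound 3 to compound 4 (0.36 log units; beyond the scatter). Set beside the same change on the core of compound 1, the step carries over with much the same size: the same change on two cores in this assay, a 1.9-fold lower number (0.27 log units; within the scatter) from compound 1 to compound 2 and a 2.3-fold lower number (0.36 log units; beyond the scatter) from compound 3 to compound 4, 1.2-fold (0.09 log units) apart, within the scatter of two such steps. Within the data shown here, this shows agreement between two cores in one assay, with only the step on the core of compound 3 beyond the scatter; it does not show that the change would behave alike on any other core.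

The compounds shown leave open whether an ethyl group or a longer chain on this nitrogen would give a similar step. They also leave open how a carboxylic acid or an amine at the end of such a chain would fare.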